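The source may hold more compounds than are shown below. What is called first, only, known or untested is meant among the compounds shown, and "the series" means these compounds.

Measured compounds in a functional assay on RAW264.7 cells (Mus musculus) for inhibition, with a stated time of 30 min; on this read-out higher numbers stand for weaker inhibition and lower numbers for stronger inhibition:

compound 1 `C=C1C(=O)OC[C@@H]1CCOC(=O)Nc1ccc(C(C)C)cc1` gives 1580 nM
compound 2 `C=C1C(=O)OC[C@H]1CCOC(=O)Nc1ccc(I)cc1` gives 490 nM
compound 3 `C=C1C(=O)OC[C@@H]1CCOC(=O)Nc1ccc(I)cc1` gives 790 nM

On the numbers shown, compound 2 stands at the lowest number of the three in this assay; its nearest neighbour is compound 3, to which a 1.6-fold higher number from compound 2 to compound 3 (0.21 log units; within the scatter) applies, the two being alike in everything except (the fact that compounds 2 and 3 differ only in the configuration as drawn). Its furthest neighbour is compound 1, where the gap is beyond the scatter.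

The step under consideration is from compound 2 to compound 4 `C=C1C(=O)OC[C@H]1CCOC(=O)Nc1ccc(Br)cc1`: bromo in place of iodo on an aromatic carbon. Of the measured steps, the one that bears most on this change of the group on the aromatic carbon is a 2.0-fold lower number from compound 1 to compound 3 (0.30 log units; within the scatter), which sits within the scatter, while a 1.6-fold higher number from compound 2 to compound 3 (0.21 log units; within the scatter) concerns configuration only. Neither step gives reason to expect a shift beyond the scatter in this assay for an exchange of one halogen for another at the same place.

Compound 4 is therefore expected to give 600 nM in this assay, with a range from 250 nM to 1500 nM. The expected step from compound 2 to compound 4 is a 1.2-fold higher number from compound 2 to compound 4 (0.09 log units; within the scatter), that is, none beyond the scatter.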

Compound 4, half-maximal inhibitory concentration: 350 nM
Compound 4: middle estimate off by 1.7-fold (0.23 log units), on the high side; measured number inside the range.
By their numbers in this assay, from the lowest: compounds 4, 2, 3 and 1 (each within the scatter of the next, the first and the last beyond it).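

In this assay, the exchange of iodo for bromo on the aromatic carbon, para to a large group, gives a 1.4-fold lower number from compound 2 to compound 4 (0.15 log units; within the scatter) and so stays within the scatter with the configuration as drawn in compound 2 held fixed. The earlier exchange at this place, a 2.0-fold lower number from compound 1 to compound 3 (0.30 log units; within the scatter), stood in the opposite configuration as drawn, so a step within the scatter is now seen at this position in both configurations. Nothing at hand gives a cause for the size of this step.

Open, on these data alone, is whether the configuration step seen between compound 2 and compound 3 recurs with bromo at this place. Also open, as far as these compounds go, is whether chloro, an amine, a carboxylic acid or a longer chain at this position would stay within the scatter of compound 2.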